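This account rests on a few compounds, and the source may have more. Where it says the series, first, only, none or still open, it means among the compounds named here.

Series notes. In an assay on isolated protein for inhibition of alpha-mannosidase (Canavalia ensiformis), tested at 1000 uM (on this read-out lower numbers stand for less inhibition and higher numbers for more inhibition at the one concentration tested (going by the name of the read-out)), compound 1 `COc1ccc([C@]2(CO)NC[C@@H](O)[C@@H]2O)cc1` gives 0.2%. Compound 2 `C[C@]1(CO)NC[C@@H](O)[C@@H]1O` gives 3.8% in this assay, and compound 3 `OC[C@@]1(c2cccc(F)c2)NC[C@@H](O)[C@@H]1O` gives 0%. Compound 1 sits between the other two numbers, but all three lie within the scatter of one another, so the three measured compounds cannot be told apart on this read-out.

Compound 4 `OC[C@@]1(c2ccc(F)cc2)NC[C@@H](O)[C@@H]1O` differs from compound 1 in one place: fluoro in place of methoxy on an aromatic carbon. Among the compounds with values here, no measured pair in the set shows the effect of this change. Compound 3 carries fluoro on the same ring and gives no measurable inhibition, so a step of about a number 0.3 percentage points higher from compound 1 to compound 4 (within the scatter) is expected, that is none beyond the scatter. Compound 4 is therefore estimated at 0.5%, with a range of 0% to 8%.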

Compound 4, a percentage reported as inhibition, at one concentration (the size of the read-out at that concentration, not a potency): 6.6%
Compound 4: middle estimate off by 6.1 percentage points, on the low side; low and high end bracket the measured number.
By their numbers in this assay, from the lowest: compounds 3, 1, 2 and 4 (each within the scatter of the next).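

Fluoro in place of methoxy gives the first direct reading at this position on the aromatic ring, and in this assay it is a number 6.4 percentage points higher from compound 1 to compound 4 (within the scatter). The two compounds therefore cannot be told apart at the one concentration tested, and this single pair shows no effect of the change on the read-out. Nothing available bears on why the step has this size.

On these data alone, whether any replacement of methoxy at this position moves the read-out beyond the scatter remains open. As far as these compounds go, what an amine or a carboxylic acid would give there also remains open.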